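The source may report more compounds than this note shows. Statements on the series, on what has been measured and on what is new or still open speak of the compounds shown alone.

Of the compounds shown here, three that share the nitrocatechol core have been measured in a functional assay on the whole organism (liver, strain NMRI) for inhibition, with Mus musculus as the target, with a stated time of 3 h, at a dose of 3 mg/kg by the oral route; on this read-out higher numbers stand for more inhibition at the one dose given (going by the name of the read-out) and lower numbers for less inhibition. Compound 1 `O=[N+]([O-])c1cc(-c2nc(N3CCN(c4ccccn4)CC3)no2)cc(O)c1O` gives 32.2%. Within the data shown here, compound 2 `CN1CCN(c2noc(-c3cc(O)c(O)c([N+](=O)[O-])c3)n2)CC1` gives 56.8%, and the only one-place step among the measured compounds, a number 24.6 percentage points higher from compound 1 to compound 2 (beyond the scatter), lies beyond the scatter. Compound 3 `Cc1cc(-c2cc(-c3cc(O)c(O)c([N+](=O)[O-])c3)on2)on1` gives 32.4% in this assay; it stands second highest of the three numbers, within the scatter of compound 1 and beyond it below compound 2.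

Compound 4 `O=[N+]([O-])c1cc(-c2cc(-c3cccnc3)no2)cc(O)c1O` differs from compound 3 in one place: pyridin-3-yl in place of 3-methyl-1,2-oxazol-5-yl on an aromatic carbon. Among the measured compounds shown here, no measured step touches this position; the one step that has been measured, from compound 1 to compound 2, concerns an amine nitrogen in a ring and says nothing about an exchange of aromatic groups on the core's five-membered ring. With nothing in the data to point either way, the step from compound 3 to compound 4 is expected to stay within the scatter, a number 0.4 percentage points lower from compound 3 to compound 4 (within the scatter). For compound 4 in this assay the estimate is therefore 32%, with a range from 15% to 50%.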

Compound 4, a percentage reported as inhibition, in the whole organism at one dose (the size of the read-out at that dose, not a potency): 33.6%
The estimate for compound 4 lay 1.6 percentage points below the measured number; the measured number falls inside the stated range.
By their numbers in this assay, from the lowest: compounds 1, 3 and 4 (each within the scatter of the next); then compound 2.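

In this assay, putting pyridin-3-yl in place of 3-methyl-1,2-oxazol-5-yl on this aromatic carbon gives a number 1.2 percentage points higher from compound 3 to compound 4 (within the scatter), so the two compounds cannot be told apart on this read-out. Among these compounds, this is the first reading at this position, which lies next to the ring nitrogen, and it shows that a six-membered aromatic ring with one hetero atom and a five-membered aromatic ring with two hetero atoms can stand here with no difference beyond the scatter at the one dose given. No measurement shown accounts for this likeness between the two groups.

Still open, as far as these compounds go, is whether a group without an aromatic ring, such as an amine, a carboxylic acid or a longer chain, would stay within the scatter on this carbon. From the compounds shown here alone, it is also open whether pyridin-4-yl would read like pyridin-3-yl here.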